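Swapping one five-membered ring for another at a limit

The source may hold more compounds than are shown below. What is called first, only, known or untested is meant among the compounds shown, and "the series" means these compounds.

Measured in a functional assay on CEM-DNR-bulk cells (Homo sapiens), read by MTT assay, with a stated time of 72 h; a lower number here means a stronger inhibitor, a higher number a weaker inhibitor:
- compound 1 `COc1ncnc2c1c(-c1ccccc1)cn2[C@@H]1O[C@H](CO)[C@@H](O)[C@H]1O`: > 20000 nM (a limit, not a number)
- compound 2 `C#Cc1cn([C@@H]2O[C@H](CO)[C@@H](O)[C@H]2O)c2ncnc(OC)c12`: 3490 nM
- compound 3 `CSc1ncnc2c1c(-c1ccoc1)cn2[C@@H]1O[C@H](CO)[C@@H](O)[C@H]1O`: > 20000 nM (a limit, not a number)

Compound 3 has no exact number, only the limit > 20000 nM. That is the limit of > 20000 nM in this assay, at which 2 of the 3 values shown sit. Compound 4 `CSc1ncnc2c1c(-c1cccs1)cn2[C@@H]1O[C@H](CO)[C@@H](O)[C@H]1O` differs from it in one place, with thiophen-2-yl in place of furan-3-yl on an aromatic carbon.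

Among the compounds with values here, no measured step makes this exchange. The nearest is an at least 5.7-fold lower number from compound 1 to compound 2 (0.75 log units; beyond the scatter), where ethynyl in place of phenyl on an aromatic carbon gave a lower number. It shows that this place can matter, but in compound 4 one five-membered aromatic ring simply replaces another, so that step is a poor guide to size. No step beyond the scatter is therefore expected in this assay, and a second limit is the likeliest result. The expected change is a number no higher from compound 3 to compound 4 (the limit leaves the size open). For compound 4 the estimated value is 20000 nM, with an expected range of 8000 nM to 40000 nM.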

Compound 4, half-maximal inhibitory concentration: > 20000 nM
Compound 4 was reported as a limit (the forecaster's own chance of this, stated with the estimate: 75%); the middle value lies on the limit itself.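

Within the data shown here, compound 3 and compound 4 are both reported only as limits, so swapping furan-3-yl for thiophen-2-yl gives no step that can be read: the limit of > 20000 nM in this assay, at which 3 of the 4 values shown sit. The compounds shown leave open whether these two rings differ in effect at all, and by how much.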